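Pyridinylmethyl ether variant of the aryloxy series

The source may hold more compounds than are shown below. What is called first, only, known or untested is meant among the compounds shown, and "the series" means these compounds.

For the measured compounds named here, compound 2 `C[C@@H](Oc1cc2oc(=O)n(CCC(=O)O)c2cc1Cl)c1cccnn1` holds the lowest of the two numbers so far in an assay for inhibition of kynurenine 3-monooxygenase (Homo sapiens), read by mass spectrometry, with a stated time of 1 h (a higher number here means a weaker inhibitor, a lower number a stronger inhibitor), giving 1.26 nM; compound 1 `COCCOc1cc2oc(=O)n(CCC(=O)O)c2cc1Cl` gives 31.6 nM. Compound 3 `O=C(O)CCn1c(=O)oc2cc(OCc3ccccn3)c(Cl)cc21` differs from compound 2 by a group of 7 heavy atoms (6 carbon, 1 nitrogen; one six-membered aromatic ring with 1 hetero atom) in place of a group of 8 heavy atoms (6 carbon, 2 nitrogen; one six-membered aromatic ring with 2 hetero atoms), on an oxygen on an aromatic ring. Going by the values given here, the one measured step on this oxygen is a 25-fold lower number from compound 1 to compound 2 (1.40 log units; beyond the scatter), which shows that a group carrying a six-membered aromatic ring is far preferred over the open chain of compound 1. Compound 3 keeps such a ring, so a large loss is not expected; a modest increase in the number is estimated, a 3.2-fold higher number from compound 2 to compound 3 (0.50 log units; beyond the scatter). Compound 3 is expected near 4 nM, within 1.3 nM to 13 nM.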

Compound 3, half-maximal inhibitory concentration: 3.16 nM
The estimate for compound 3 lay 1.3-fold (0.10 log units) above the measured number; low and high end bracket the measured number.
By their numbers in this assay, from the lowest: compound 2; then compound 3; then compound 1.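

The advantage over the open chain does not need the second ring hetero atom or the defined stereocentre: (pyridin-2-yl)methyl alone gives a 10-fold lower number from compound 1 to compound 3 (1.00 log units; beyond the scatter). Still, a 2.5-fold higher number from compound 2 to compound 3 (0.40 log units; beyond the scatter) shows that compound 2 keeps an edge beyond the scatter, though this step changes the ring and removes the stereocentre together, so neither change can be read alone. No available evidence explains these differences.

Open, from the compounds shown here alone, is whether a ring nitrogen matters at all, which a benzyl group on this oxygen would test. Also open, going by these compounds, is what an unbranched pyridazinylmethyl group or the opposite stereoisomer of compound 2 would give.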